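A few compounds are considered here, and "the series" means these few. Any claim that something is new, unique, unknown or untested is made for them only; others in the source may bear on it.

Values measured in a functional assay on MV4-11 cells (Homo sapiens) for antiproliferative activity, read by CCK-8 assay, with a stated time of 72 h (on this read-out higher numbers stand for weaker inhibition and lower numbers for stronger inhibition), so far:
- compound 1 (`CC(C)Oc1ccc(C(C)(C)O)cc1-c1cn(C)c(=O)c2[nH]c(C(=O)NCc3ccc(C(=O)Nc4ccccc4N)cc3)cc12`): 40 nM
- compound 2 (`COc1cccc(-c2cn(C)c(=O)c3[nH]c(C(=O)NCc4ccc(C(=O)Nc5ccccc5N)cc4)cc23)c1`): 250 nM

Compound 2 has the higher of the two numbers, and its gap to compound 1 lies beyond the scatter. Compound 3 (`COc1ccc(C(C)(C)O)cc1-c1cn(C)c(=O)c2[nH]c(C(=O)NCc3ccc(C(=O)Nc4ccccc4N)cc3)cc12`) has not been measured. It differs from compound 2 by 5-(1-hydroxy-1-methylethyl)-2-methoxyphenyl in place of 3-methoxyphenyl on an aromatic carbon in a single place, with 5-(1-hydroxy-1-methylethyl)-2-methoxyphenyl in place of 3-methoxyphenyl on an aromatic carbon. Compound 1 (40 nM) also carries the 1-hydroxy-1-methylethyl group, which compound 2 lacks, but these two compounds alone cannot separate that group from their other difference. In this assay a step to a lower number is expected, and the estimated change a 4.2-fold lower number from compound 2 to compound 3 (0.62 log units; beyond the scatter) would lie beyond the scatter. The expected value for compound 3 is 60 nM within an estimated range of 25 nM to 140 nM for now.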

Compound 3, half-maximal inhibitory concentration: 420 nM
Beside the measured number, compound 3's estimate is 7.0-fold (0.85 log units) below it; the whole stated range lies below it.
By their numbers in this assay, from the lowest: compound 1; then compounds 2 and 3 (each within the scatter of the next).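

With the alkoxy group on the ring changed as well, 5-(1-hydroxy-1-methylethyl)-2-methoxyphenyl in place of 3-methoxyphenyl on this aromatic carbon gives a 1.7-fold higher number from compound 2 to compound 3 (0.23 log units; within the scatter) in this assay and so the methoxy-bearing aryl groups of these two compounds read alike. The alkyl group on the oxygen on the aromatic ring is the sharper handle here: methyl in place of isopropyl gives an 11-fold higher number from compound 1 to compound 3 (1.02 log units; beyond the scatter) and so the low number of compound 1 goes with the isopropyl group, not with the 1-hydroxy-1-methylethyl group alone. No measured evidence bears on the origin of either step.

Going by these compounds, whether an ethyl or a cyclopentyl group on that oxygen would read nearer to compound 1 or to compound 3 stays open. Also open, on these data alone, is whether the isopropyl step holds on a ring without the 1-hydroxy-1-methylethyl group.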